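The source may hold more compounds than are shown below. What is called first, only, known or untested is meant among the compounds shown, and "the series" means these compounds.

Of the compounds shown here, three sharing one core have been measured in a functional assay on LOX IMVI cells (Homo sapiens) for inhibition, read by sulforhodamine B assay, with a stated time of 48 h; on this read-out lower numbers stand for stronger inhibition of growth and higher numbers for weaker inhibition of growth. Compound 1, `O=C(Nc1cccc(-n2cc(-c3ccncc3)c(-c3ccc(Cl)c(O)c3)n2)c1)Nc1ccc(Cl)c(Cl)c1`, gives 939 nM. Compound 3, `O=C(Nc1cccc(-n2cc(-c3ccncc3)c(-c3ccc(Cl)c(O)c3)n2)c1)Nc1cc(C(F)(F)F)cc(C(F)(F)F)c1`, gives 712 nM. Compound 2, `COc1cc(-c2nn(-c3cccc(NC(=O)c4cccc(C(F)(F)F)c4)c3)cc2-c2ccncc2)ccc1Cl`, gives 1390 nM; this is the highest of the three numbers, yet its gaps to compound 1 and to compound 3 both lie within the usual scatter of this assay, so the three cannot be told apart on the data at hand.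

Compound 4, `COc1cc(-c2nn(-c3cccc(NC(=O)c4ccccc4)c3)cc2-c2ccncc2)ccc1Cl`, differs from compound 2 in a single place: hydrogen in place of trifluoromethyl on an aromatic carbon. No measured pair among these compounds shows this kind of change, so there is no earlier step to set the size of this one against. With the trifluoromethyl gone and a hydrogen in its place, the expectation is a small step, not clearly beyond the scatter, if anything toward a higher number. Compound 4 is therefore expected to give about 1800 nM, within a range from 700 nM to 4500 nM. The expected step is a 1.3-fold higher number from compound 2 to compound 4 (0.11 log units; within the scatter).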

Compound 4, concentration for 50% growth inhibition: 567 nM
The estimate for compound 4 lay 3.2-fold (0.50 log units) above the measured number; the measured number lies below the stated range.
By their numbers in this assay, from the lowest: compounds 4, 3, 1 and 2 (each within the scatter of the next, the first and the last beyond it).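

Going from 3-(trifluoromethyl)phenyl to phenyl gives a 2.5-fold lower number from compound 2 to compound 4 (0.39 log units; beyond the scatter) in this assay. For the compounds shown here, this is the first difference that rises above the scatter, and it comes from a single change in one place, whereas the earlier compounds could not be told apart. At this position, then, the trifluoromethyl is not needed for growth inhibition in these cells, and the compound with hydrogen there does better; no measurement at hand explains this gain.

This single pair cannot show whether a small group such as methyl, or an amine or a carboxylic acid, would match hydrogen at this carbon or go further. It also leaves open whether removing trifluoromethyl would act the same way on compound 3.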